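Taking the chloro off compound 3

This account rests on a few compounds, and the source may have more. Where it says the series, first, only, none or still open, it means among the compounds named here.

In a functional assay on Hep cells (Homo sapiens) for cytotoxicity, read by sulforhodamine B assay, with a stated time of 48 h (on this read-out higher numbers stand for weaker inhibition and lower numbers for stronger inhibition), compound 1 (`C=CCOc1ccc(F)cc1C(=O)c1cccnc1`) gives > 100000 nM as a limit and not a number. Compound 3 (`C=CCOc1ccc(Cl)cc1C(=O)c1cccnc1`) gives > 100000 nM and this too is only a limit, so its true place on the scale is not known. The small set is thus dominated by the limit of > 100000 nM in this assay, at which 2 of the 3 values shown sit, and little finer can be read from it. Compound 2 (`C=CCOc1c(Cl)cccc1C(=O)c1cccnc1`) alone gives an actual number, at 92000 nM for the same shared core.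

Compound 4 (`C=CCOc1ccccc1C(=O)c1cccnc1`) has hydrogen in place of chloro on an aromatic carbon of compound 3 (hydrogen in place of chloro on an aromatic carbon). Going by the values given here, the only measured step that bears on this change is a step that the two limits leave unreadable from compound 1 to compound 3 and it offers no size to carry over. What remains is that compound 2 at 92000 nM shows a chloro-bearing member of this set giving a number only at the far weak end of the scale. No step beyond the scatter is therefore expected, and no clear direction. For this change the estimated step is a step that the limit leaves unreadable from compound 3 to compound 4 and it remains an expectation. In this assay compound 4 is expected to read 110000 nM with an estimated range of 50000 nM to 200000 nM and a good chance of returning only a limit.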

Compound 4, half-maximal inhibitory concentration: > 100000 nM
Compound 4 was reported as a limit; the forecaster's own chance of this, stated with the estimate: 65%; the middle value is on the limit's open side.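

Compound 4 carries no halogen on the ring that held the chloro of compound 3, and its result is again a limit rather than a number. Hydrogen on the carbon para to an allyloxy group therefore does not bring a readable value in this assay, and neither chloro nor fluoro at that place can yet be told apart from hydrogen. Going by these compounds alone, the one step that can be read is an at least 1.0-fold higher number from compound 2 to compound 4 (0.03 log units; that floor lies within the scatter), so the same swap made from compound 2 shows no change that stands out from repeat-measurement noise, while the steps from compound 1 and compound 3 to compound 4 cannot be read because most of this small set rests at one ceiling: the limit of > 100000 nM in this assay, at which 3 of the 4 values shown sit.

The compounds shown leave open whether any group at this place can bring the reading to a clear number well inside the scale, or whether the whole set stays at the weak end whatever sits there. An amine or a carboxylic acid on that carbon, or a longer chain in place of the allyloxy group, would put that question to the test.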